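Working notes: from compound 3 to compound 4

This account rests on a few compounds, and the source may have more. Where it says the series, first, only, none or still open, it means among the compounds named here.

Compound 1 `O=C(CCc1cccc2c1B(O)OC2)Nc1ccccc1` gives 350 nM in a functional assay on HCT-116 cells (Homo sapiens) for antiproliferative activity, read by MTT assay, with a stated time of 72 h (on this read-out lower numbers stand for stronger inhibition and higher numbers for weaker inhibition), and has the lowest number of the three measured compounds. Compound 2 `Cc1ccc(NC(=O)CCc2cccc3c2B(O)OC3)cc1` stands at 4500 nM and compound 3 `COc1ccc(NC(=O)CCc2cccc3c2B(O)OC3)cc1` at 1700 nM there, which makes compound 3 the second highest of the three numbers.

Compound 4 `CC(C)(C)OC(=O)Nc1ccc(NC(=O)CCc2cccc3c2B(O)OC3)cc1` has not yet been measured. It carries (tert-butoxycarbonyl)amino in place of the methoxy of compound 3 on an aromatic carbon, para to a large group (tert-butoxycarbonyl)amino in place of methoxy on an aromatic carbon in the structural count.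

Among the compounds with values here, three measured steps bear on this change. Methyl in place of hydrogen gave a 13-fold higher number from compound 1 to compound 2 (1.11 log units; beyond the scatter) as a large step, and methoxy in place of hydrogen gave a 4.9-fold higher number from compound 1 to compound 3 (0.69 log units; beyond the scatter) as a modest one. Methoxy in place of methyl gave a 2.6-fold lower number from compound 2 to compound 3 (0.42 log units; beyond the scatter) as a further modest step, so the number depends on the group present. Within the data shown here, no measured compound carries the incoming group, and the two substituted compounds offer only a rough guide.

The expected change in this assay is a 2.4-fold higher number from compound 3 to compound 4 (0.37 log units; beyond the scatter) and is a modest move towards a higher number. For compound 4 the estimated value is 4000 nM with an expected range from 1000 nM to 15000 nM on the present data.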

Compound 4, half-maximal inhibitory concentration: 24000 nM
Beside the measured number, compound 4's estimate is 6.0-fold (0.78 log units) below it, and the stated range ends below it.
By their numbers in this assay, from the lowest: compound 1; then compound 3; then compound 2; then compound 4.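

In this assay the group on this aromatic carbon can move the number well past what methyl and methoxy showed: (tert-butoxycarbonyl)amino gives a 14-fold higher number from compound 3 to compound 4 (1.15 log units; beyond the scatter) and a 5.3-fold higher number from compound 2 to compound 4 (0.73 log units; beyond the scatter) in the comparison with the methyl compound, which leaves compound 4 with the highest number of the four. Set against hydrogen, the change is a 69-fold higher number from compound 1 to compound 4 (1.84 log units; beyond the scatter) and it is the largest step in the set, so all three groups on this carbon stand above compound 1, with none of them going against that order. Nothing measured here bears on why the number rises with this group.

The compounds shown leave open whether the rise belongs to the whole (tert-butoxycarbonyl)amino group or to a part of it, a question that the free amine or an acetamide on the same carbon would help to separate. Also open, from the compounds shown here alone, is whether a halogen such as fluorine or chlorine, or a carboxylic acid, would stay close to compound 1 at 350 nM or move towards the higher numbers of the other three compounds.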